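Esterifying the hydroxymethyl of compound 2

The compounds below may be only part of what the source reports. "The series", "measured", "known", "first", "only" and "open" are said of these compounds alone.

Of the compounds shown here, three on a shared core have been tested so far. Within the data shown here, in a functional assay on PA-1 cells (Homo sapiens) for cytotoxicity, read by MTT assay, with a stated time of 4 h (on this read-out lower numbers stand for stronger inhibition and higher numbers for weaker inhibition), compound 1 `COC(=O)C1=CO[C@@H](O[C@@H]2O[C@H](COC(c3ccccc3)(c3ccccc3)c3ccccc3)[C@@H](O)[C@H](O)[C@H]2O)[C@@H]2[C@@H](C)[C@@H](O)C[C@H]12` gives 0.65 ug/mL, the only number. Compound 2 `COC(=O)C1=CO[C@@H](O[C@@H]2O[C@H](CO)[C@@H](OC(C)=O)[C@H](OC(C)=O)[C@H]2OC(C)=O)[C@@H]2[C@@H](C)[C@@H](OC(C)=O)C[C@H]12` has no single number and is recorded as "not active" (no number reported). Compound 3 `CCCCCCCCCCCCCCCC(=O)OC[C@H]1O[C@@H](O[C@@H]2OC=C(C(=O)OC)[C@H]3C[C@H](OC(C)=O)[C@H](C)[C@@H]23)[C@H](OC(C)=O)[C@@H](OC(C)=O)[C@@H]1OC(C)=O` is recorded the same way, as "not active" (no number reported), so the two cannot be ranked against each other.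

Compound 4 `COC(=O)C1=CO[C@@H](O[C@@H]2O[C@H](COC(=O)C=C(C)C)[C@@H](OC(C)=O)[C@H](OC(C)=O)[C@H]2OC(C)=O)[C@@H]2[C@@H](C)[C@@H](OC(C)=O)C[C@H]12` is next in this assay. The change is (2-methylprop-1-en-1-yl)carbonyl in place of hydrogen on an oxygen on a saturated carbon, which turns hydroxymethyl into (((2-methylprop-1-en-1-yl)carbonyl)oxy)methyl. Among the measured compounds shown here, no measured pair isolates this change, so the expected step rests on thin evidence. Starting from compound 2 at "not active" (no number reported), the likeliest outcome is no clear gain, with no number reported again. If a number does appear, it is expected to be weak, on the higher side of compound 1 at 0.65 ug/mL. For compound 4 the estimated value is 10 ug/mL, with an expected range of 1.5 ug/mL to 60 ug/mL.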

Compound 4, half-maximal inhibitory concentration: 0.65 ug/mL
Estimate against measurement, compound 4: 15-fold (1.19 log units) above; the whole stated range lies above it.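

Among these compounds, compound 2 carries no number, only a "not active" record, so no step to compound 4 can be read. The compounds shown leave open what the change to (((2-methylprop-1-en-1-yl)carbonyl)oxy)methyl alone does, with no pair of numbers isolating it. No evidence on hand bears on this result.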